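Hydrazine sulfonamide series: chloro for cyano on compound 3

The source may hold more compounds than are shown below. What is called first, only, known or untested is meant among the compounds shown, and "the series" means these compounds.

Three compounds have a number in an assay for inhibition of Indoleamine 2,3-dioxygenase 1 (Homo sapiens), read by spectrophotometry, with stated times of 1 h and 4 h; a lower number here means a stronger inhibitor, a higher number a weaker inhibitor. Compound 1 `Cc1cccc(NNS(=O)(=O)c2ccc(C(=O)NCC(=O)O)cc2)c1` gives 80 nM in this assay, and compound 2 `Cc1cccc(NNS(=O)(=O)c2ccc(C#N)cc2)c1` gives 59 nM. Among the compounds with values here, the one measured step among them, a 1.4-fold lower number from compound 1 to compound 2 (0.13 log units; within the scatter), changes a group on the sulfonyl-bearing ring and is within the scatter. Compound 3 `CC(=O)Nc1ccc(S(=O)(=O)NNc2ccc(C#N)cc2)cc1` gives 5670 nM, the highest of the three numbers and the weakest inhibitor of the set, lying well beyond the scatter from both compound 1 and compound 2 in this assay.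

Compound 4 `CC(=O)Nc1ccc(S(=O)(=O)NNc2ccc(Cl)cc2)cc1` is not yet measured. It differs from compound 3 by chloro in place of cyano on an aromatic carbon. Within the data shown here, no measured step among the three compounds exchanges a substituent on the hydrazine-bearing ring, and none exchanges cyano for chloro anywhere, so the step from compound 1 to compound 2 is only a distant point of reference and does not bear directly on this change. Among the measured compounds shown here, with no precedent in the set, the working expectation for this assay is no change beyond the scatter, in either direction; the expected step is a 1.3-fold lower number from compound 3 to compound 4 (0.10 log units; within the scatter). Compound 4 is therefore estimated at 4500 nM in this assay, with a range from 1500 nM to 15000 nM.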

Compound 4, half-maximal inhibitory concentration: 155 nM
Estimate against measurement, compound 4: 29-fold (1.46 log units) above; the measured number lies below the stated range.
By their numbers in this assay, from the lowest: compounds 2, 1 and 4 (each within the scatter of the next, the first and the last beyond it); then compound 3.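

Cyano at this place, para to a large group, is not interchangeable with chloro: the exchange gives a 37-fold lower number from compound 3 to compound 4 (1.56 log units; beyond the scatter) in this assay and is the first measured change on the hydrazine-bearing ring. Within the data shown here, the only earlier step, a 1.4-fold lower number from compound 1 to compound 2 (0.13 log units; within the scatter) in this assay, lies on the sulfonyl-bearing ring and within the scatter, so the series now has one position where a single substituent exchange moves the number well beyond the scatter, though this rests on one pair of compounds. Nothing available on these compounds accounts for the size of this step.

As far as these compounds go, it remains open whether the lower number is particular to chloro or would also appear with another group at this place, such as bromo, methoxy, an amine or a carboxylic acid. Among these compounds, it is also open whether the same exchange gives a step of similar size when the acetamido group on the sulfonyl-bearing ring is replaced by the nitrile or the (carboxymethyl)carbamoyl group carried by the earlier compounds.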